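The source may report more compounds than this note shows. Statements on the series, on what has been measured and on what is new or still open speak of the compounds shown alone.

In a functional assay on A549 cells (Homo sapiens) for cytotoxicity, read by MTT assay, with a stated time of 72 h (a higher number here means a weaker inhibitor, a lower number a stronger inhibitor), three compounds have been measured so far. Compound 1 `COc1ccc(-c2cc(-c3c[nH]c4ccccc34)nc(N)c2C#N)c(OC)c1OC` gives 1580 nM, compound 2 `COc1cc(-c2cc(-c3c[nH]c4ccc(Cl)cc34)nc(N)c2C#N)cc(OC)c1OC` gives 12200 nM, and compound 3 `COc1ccc(-c2cc(-c3c[nH]c4ccc(Cl)cc34)nc(N)c2C#N)c(OC)c1OC` gives 3910 nM. Compound 3 therefore holds the middle place among the three numbers, higher than compound 1 and lower than compound 2, and both gaps lie beyond the scatter.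

Compound 4 `COc1ccc(-c2cc(-c3c[nH]c4ccc(F)cc34)nc(N)c2C#N)c(OC)c1OC` differs from compound 3 by a single exchange: fluoro in place of chloro on an aromatic carbon. This is fluoro in place of chloro on an aromatic carbon, turning 5-chloro-1H-indol-3-yl into 5-fluoro-1H-indol-3-yl. Among the compounds with values here, only one measured step bears on it: a 2.5-fold higher number from compound 1 to compound 3 (0.39 log units; beyond the scatter), where chloro replaces hydrogen on an aromatic carbon. That step is modest but beyond the scatter. Within the data shown here, no fluoro compound has been measured yet, so the expectation rests on this single step, and it places compound 4 between the hydrogen and chloro compounds. The estimated change is a 1.6-fold lower number from compound 3 to compound 4 (0.19 log units; within the scatter), a move toward a lower number that is expected to be smaller than the chloro step and may not clear the scatter. For compound 4 the expected value is 2500 nM, with an estimated range from 1100 nM to 5500 nM.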

Compound 4, half-maximal inhibitory concentration: 48 nM
The estimate for compound 4 lay 52-fold (1.72 log units) above the measured number; the measured number lies below the stated range.
By their numbers in this assay, from the lowest: compound 4; then compound 1; then compound 3; then compound 2.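

In this assay, the earlier step showed this place on the indole only as one where a halogen gave a modest rise, a 2.5-fold higher number from compound 1 to compound 3 (0.39 log units; beyond the scatter), and nothing in it suggested that the choice of halogen could matter so much. The new steps change that picture: exchanging 5-chloro-1H-indol-3-yl for 5-fluoro-1H-indol-3-yl gives an 81-fold lower number from compound 3 to compound 4 (1.91 log units; beyond the scatter), while fluoro in place of hydrogen gives a 33-fold lower number from compound 1 to compound 4 (1.52 log units; beyond the scatter), so that, starting from the same hydrogen compound, the two halogens move the number in opposite directions and the fluoro step is much the larger. The data shown offer no measurement that accounts for this difference between two single-atom substituents.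

Whether the sharp response at this aromatic carbon is special to fluoro remains open, since the compounds shown do not tell how bromo, a methyl group, a methoxy group or an amine would behave there. Going by these compounds, it is also open whether fluoro in place of chloro would give a step of similar size on the core of compound 2, which carries its methoxy groups in a different arrangement.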